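A few compounds are considered here, and "the series" means these few. Any claim that something is new, unique, unknown or untested is made for them only; others in the source may bear on it.

Measured so far:
compound 1, `CC(=O)Nc1ccc(S(=O)(=O)Oc2ccccc2I)cc1` — 17000 nM
compound 2, `O=C(CCl)Nc1ccc(S(=O)(=O)Oc2ccccc2I)cc1` — 600 nM

Both compounds share one core and differ only in the group on the saturated chain carbon bound to the carbonyl carbon. For the measured compounds named here, in a functional assay on HT-1080 cells (Homo sapiens) for antiproliferative activity, read by sulforhodamine B assay, with a stated time of 48 h (on this read-out higher numbers stand for weaker inhibition and lower numbers for stronger inhibition), compound 2 gives the lowest of the two numbers, and the only measured step, a 28-fold lower number from compound 1 to compound 2 (1.45 log units; beyond the scatter), is the one that leads to it. Compound 3, `O=C(CCCl)Nc1ccc(S(=O)(=O)Oc2ccccc2I)cc1`, carries the change (chloromethyl in place of chloro on a saturated chain carbon bound to a carbonyl carbon). Going by the values given here, no measured step moves the chloro one carbon further out, so the data only show that placing a chloro directly on that carbon mattered greatly; they do not show what lengthening the chain does. The expectation for compound 3 is therefore uncertain and is set toward a higher number than compound 2, as an 8.3-fold higher number from compound 2 to compound 3 (0.92 log units; beyond the scatter). For compound 3 the estimate in this assay is 5000 nM, with a range from 800 nM to 25000 nM.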

Compound 3, half-maximal inhibitory concentration: 4200 nM
Compound 3: the middle estimate sits 1.2-fold (0.08 log units) above what was measured; low and high end bracket the measured number.
By their numbers in this assay, from the lowest: compound 2; then compound 3; then compound 1.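

In this assay, moving the chloro one carbon further out, so that chloromethyl gives way to 2-chloroethyl, brings a 7.0-fold higher number from compound 2 to compound 3 (0.85 log units; beyond the scatter), which shows that where the chloro sits on the chain matters and not only whether it is present. The longer group still keeps part of the gain over plain hydrogen, with a 4.0-fold lower number from compound 1 to compound 3 (0.61 log units; beyond the scatter), so both chloro-bearing chains give lower numbers than compound 1, and the shorter one gives the lowest. No supporting measurement is available to explain why this chain change shifts the number.

As far as these compounds go, it remains open whether the chloro itself is needed, which a bromo, a hydroxyl or an amine on the same carbon could test. A longer chain ending in chloro could show whether the number keeps climbing as the chloro moves further out.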